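Swapping Acetyl for Dimethylamino in a Cytotoxicity Screen

The compounds below may be only part of what the source reports. "The series", "measured", "known", "first", "only" and "open" are said of these compounds alone.

Compound 1 `COc1cc(C)cc(-c2c(-c3ccnc(-c4ccc(C(C)=O)cc4)c3)cnn2CC#N)c1` was tested in a functional assay on NCI-H460 cells (Homo sapiens) for cytotoxicity, read by sulforhodamine B assay, with a stated time of 48 h, tested at 0.01 uM (a higher number here means a weaker effect of the compound at the concentration tested, a lower number a stronger effect), and gives 98%. Compound 2 `Cc1cc(O)cc(-c2nn(CC#N)cc2-c2ccnc(-c3ccc(N(C)C)cc3)c2)c1` in this assay gives 102%; the two numbers lie within the scatter of each other, so at this concentration neither compound can be told apart from the other. Compound 3 `COc1cc(C)cc(-c2c(-c3ccnc(-c4ccc(N(C)C)cc4)c3)cnn2CC#N)c1` has not yet been measured in this assay. It differs from compound 1 in one place: dimethylamino in place of acetyl on an aromatic carbon. Going by the values given here, no step between measured compounds covers this change. Compound 2 already carries dimethylamino and gives 102%. The step is therefore expected to be a number 2 percentage points higher from compound 1 to compound 3 (within the scatter), none beyond the scatter. Compound 3 is expected to give 100% in this assay, between 88% and 110%.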

Compound 3, a percentage reported as activity, at one concentration (the size of the read-out at that concentration, not a potency): 35%
Estimate against measurement, compound 3: 65 percentage points above, outside the stated range (below it).
By their numbers in this assay, from the lowest: compound 3; then compounds 1 and 2 (each within the scatter of the next).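

On the 4-acetylphenyl to 4-(dimethylamino)phenyl change, this assay shows a number 63 percentage points lower from compound 1 to compound 3 (beyond the scatter), so this position matters for the read-out at this concentration. The dimethylamino group does not give this result in every compound shown: compound 2 also carries it, with hydroxyl in place of methoxy, and gives 102%. Nothing measured here accounts for the step. Going by these compounds, it remains open whether a primary amine, a morpholine ring or a carboxylic acid at this position would give a similar read-out. On these data alone, how compound 3 behaves at other concentrations also remains open.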